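The compounds below may be only part of what the source reports. "The series", "measured", "known", "first", "only" and "open" are said of these compounds alone.

Working notes on the series. Compound 1 `C=C1C[C@]23C[C@@]1(O)CC[C@H]2c1ccc(O)c(C)c1[C@@H]3Cn1cc(-c2ccc(C(F)(F)F)cc2)nn1` has a shared core carrying a free phenol, a methyl on the aromatic ring and a triazole bearing a 4-(trifluoromethyl)phenyl group. In a functional assay on SW480 cells (Homo sapiens) for cytotoxicity, read by MTT assay, with a stated time of 4 days (on this read-out lower numbers stand for stronger inhibition and higher numbers for weaker inhibition), compound 1 gives > 20000 nM, which is a limit of the assay rather than a number. Compound 2 `C=C1C[C@]23C[C@@]1(O)CC[C@H]2c1ccc(OS(=O)(=O)c2ccc(C)cc2)c(C)c1[C@@H]3Cn1cc(-c2ccccc2)nn1` keeps the same core, with the phenol capped as a toluenesulfonate ester and a plain phenyl on the triazole. In this assay compound 2 gives > 20000 nM, again a limit of the assay and not a number. Where compound 2 stands can only be said against that limit: both values shown sit at it, as summarised by the limit of > 20000 nM in this assay, at which 2 of the 2 values shown sit. Among the measured compounds shown here, no step between measured compounds can be computed from these two limits.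

Compound 3 `C=C1C[C@]23C[C@@]1(O)CC[C@H]2c1ccc(OS(=O)(=O)c2ccc(C)cc2)c(C)c1[C@@H]3Cn1cc(-c2ccc(C(F)(F)F)cc2)nn1` combines the toluenesulfonate ester of compound 2 with the 4-(trifluoromethyl)phenyl of compound 1; against compound 2 the change is trifluoromethyl in place of hydrogen on an aromatic carbon. Neither measured value offers a direction. The step of a number no higher from compound 2 to compound 3 (the limit leaves the size open) is expected to be none beyond the scatter. Compound 3 is accordingly estimated at 20000 nM, within 10000 nM to 40000 nM, and most probably reported once more as a limit.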

Compound 3, half-maximal inhibitory concentration: > 20000 nM
Compound 3 ended at the assay's limit (the forecaster's own chance of this, stated with the estimate: 85%); the middle value lies on the limit itself.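

No step can be read between compound 3 and either compound 1 or compound 2, since each of the three values is a limit of the assay and not a number. The compounds shown leave open whether the trifluoromethyl or the toluenesulfonate ester changes cytotoxicity at all, with every value at one limit: the limit of > 20000 nM in this assay, at which 3 of the 3 values shown sit.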